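A few compounds are considered here, and "the series" means these few. Any claim that something is new, unique, unknown or untested is made for them only; others in the source may bear on it.

Measured compounds:
- compound 1, `CCCn1ccc2cc(-c3ccc(OC)nc3)cc(Cl)c2c1=O`: 794 nM
- compound 2, `CCCn1ccc2cc(-c3cnc(OC)c(F)c3)cc(Cl)c2c1=O`: 398 nM

Both compounds were tested in a functional assay on CHO cells for agonist activity at metabotropic glutamate receptor 2 (Homo sapiens), read by GTPgammaS binding; a higher number here means that more compound is needed for the effect, a lower number that less compound is needed. Compound 1 gives 794 nM, the higher of the two numbers, while compound 2 gives 398 nM; the step of a 2.0-fold lower number from compound 1 to compound 2 (0.30 log units; within the scatter) is within the scatter, so the two compounds cannot be told apart on these numbers.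

Compound 3, `CCCn1ccc2cc(-c3ccc(OCCc4ccccc4)nc3)cc(Cl)c2c1=O`, has not yet been measured. It differs from compound 1 by benzyl in place of hydrogen on a saturated chain carbon bound to an oxygen on an aromatic ring. Within the data shown here, this is a much larger addition than the single-atom swap that separates compound 1 from compound 2, and that one measured step concerns a different place on the molecule, so no measured step in this set bears on the change to compound 3. With nothing to lean on, the direction of the step is open: the number for compound 3 could sit near that of compound 1 or move well away in either sense. Compound 3 is therefore expected to give 1000 nM, somewhere between 150 nM and 6000 nM, which as a step from compound 1 means an expected 1.3-fold higher number from compound 1 to compound 3 (0.10 log units; within the scatter).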

Compound 3, half-maximal effective concentration: 631 nM
Beside the measured number, compound 3's estimate is 1.6-fold (0.20 log units) above it, and the stated range covers the measured number.
By their numbers in this assay, from the lowest: compounds 2, 3 and 1 (each within the scatter of the next).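

Growing the methoxy group of compound 1 into the phenethyloxy group of compound 3 gives, in this assay, a 1.3-fold lower number from compound 1 to compound 3 (0.10 log units; within the scatter) and so leaves the two compounds indistinguishable on these numbers. Among these compounds, the earlier fluoro step concerned another place on the molecule, so this is the first reading at a saturated chain carbon bound to an oxygen on an aromatic ring. There, a benzyl of 7 heavy atoms, carrying a six-membered aromatic ring of carbon only, enters in place of a single hydrogen with no change in the number that stands clear of the scatter, and no supporting data at hand explain this result.

With a single group at this position, the compounds shown leave open whether the same holds for other groups there, such as an amine or a carboxylic acid at the end of the chain, or a longer chain ending in the same phenyl ring. They also leave open what happens when the phenethyloxy group and the fluoro of compound 2 stand on one molecule, since each change has been read only on its own.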